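Swapping a Thiophene Ketone for a Chlorophenyl Ketone

The compounds below may be only part of what the source reports. "The series", "measured", "known", "first", "only" and "open" are said of these compounds alone.

Compound 1 `COC(=O)c1cc(-c2cccc(NC(=O)c3ccc(/C=C/C(=O)c4cccs4)cc3)c2)on1`: an ADME assay on Vero cells (Chlorocebus sabaeus) for cytotoxicity, read by MTT assay, with a stated time of 72 h; a lower number here means that less compound is tolerated, a higher number that more compound is tolerated "not determined" (no result reported)
Compound 2 `COC(=O)c1cc(-c2cccc(NC(=O)c3ccc(/C=C/C(=O)c4cc(F)ccc4F)cc3)c2)on1`: this assay > 40 ug/mL
Compound 3 `COC(=O)c1cc(-c2cccc(NC(=O)c3ccc(/C=C/C(=O)c4ccc(C)c(F)c4)cc3)c2)on1`: this assay > 50 ug/mL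

Compound 1 has no number of its own in this assay. Compound 2 gives > 40 ug/mL there, which is a limit of the assay rather than a measured number. Compound 3 likewise gives > 50 ug/mL, again a limit and not a number. Going by the values given here, the one step among the measured compounds is a step that the two limits leave unreadable from compound 2 to compound 3, so no size can be read from it. Among the compounds with values here, the only evidence on hand is therefore the limit of > 40 ug/mL in this assay, at which 1 of the 3 values shown sits, and (the limit of > 50 ug/mL in this assay, at which 1 of the 3 values shown sits), both of which say that the tested amount was tolerated.

Compound 4 `COC(=O)c1cc(-c2cccc(NC(=O)c3ccc(/C=C/C(=O)c4cccc(Cl)c4)cc3)c2)on1` carries 3-chlorophenyl in place of thiophen-2-yl on a carbonyl carbon. Nothing measured bears directly on this change, so no step beyond the scatter is expected in this assay. Compound 4 is therefore expected to sit near the same limits, with an estimate of 60 ug/mL (range 30 ug/mL to 150 ug/mL), and a reported limit rather than a number is the likelier outcome.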

Compound 4, half-maximal cytotoxic concentration: > 2.5 ug/mL
Compound 4: no number, only a limit; the forecaster's own chance of this, stated with the estimate: 70%; the middle value is on the limit's open side.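

In this assay compound 4 gives > 2.5 ug/mL, which is a limit and not a number. Its steps from compound 2 and from compound 3 cannot be read. The compounds shown leave open whether 3-chlorophenyl on the carbonyl carbon changes how much compound the cells tolerate.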